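From compound 2 to compound 3, starting at a limit

This account rests on a few compounds, and the source may have more. Where it says the series, first, only, none or still open, it means among the compounds named here.

In a functional assay on SH-SY5Y cells (Homo sapiens) for antiproliferative activity, read by MTT assay, with a stated time of 72 h (a higher number here means a weaker inhibitor, a lower number a stronger inhibitor), compound 1 `COc1cc2c(Nc3ccc(C#N)cc3)ncnc2cc1OCCCN(C)Cc1ccccc1` gives > 100000 nM, which is a limit of the assay and not a number. Compound 2 `COc1cc2c(Nc3ccc(C#N)cc3)ncnc2cc1OCCCN1CCCCC1CCO` gives > 100000 nM in this assay, and this too is only a limit. Compound 2 therefore stands at the limit of > 100000 nM in this assay, at which 2 of the 2 values shown sit, with no number to place it against anything else.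

Compound 3 `COc1cc2c(Nc3ccc(C#N)cc3)ncnc2cc1OCCCN1CCC(N2CCCCC2)CC1` keeps the shared core and differs from compound 2 in one place, on a saturated chain carbon, three bonds along the chain from an oxygen on an aromatic ring: 4-(piperidin-1-yl)piperidin-1-yl in place of 2-(2-hydroxyethyl)piperidin-1-yl on a saturated chain carbon, three bonds along the chain from an oxygen on an aromatic ring. Going by the values given here, the one measured step at this place is a step that the two limits leave unreadable from compound 1 to compound 2, so it offers no size to carry over.

With so little to go on, the most likely outcome is another reading at the limit. Any readable number would lie on the stronger side, and only modestly so. The expected step in this assay is an at least 1.4-fold lower number from compound 2 to compound 3 (0.15 log units; that floor lies within the scatter), a small estimate held with low confidence. For compound 3 the estimated value is 70000 nM, expected to fall between 20000 nM and 100000 nM.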

Compound 3, half-maximal inhibitory concentration: 9810 nM
For compound 3 the middle estimate is 7.1-fold (0.85 log units) above the measured one; the measured number lies below the stated range.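

At this place, on a saturated chain carbon, three bonds along the chain from an oxygen on an aromatic ring, 4-(piperidin-1-yl)piperidin-1-yl gives the only readable number among the compounds shown in this assay, with an at least 10-fold lower number from compound 2 to compound 3 (1.00 log units; beyond the scatter) and an at least 10-fold lower number from compound 1 to compound 3 (1.00 log units; beyond the scatter). The step between compound 1 and compound 2 cannot be read, so only compound 3 shows that the group on this chain can bring the read-out off the limit of the assay. Both readable steps are floors and not full sizes, since each starts from a limit and not a number: the limit of > 100000 nM in this assay, at which 2 of the 3 values shown sit.

The compounds shown leave open which feature of 4-(piperidin-1-yl)piperidin-1-yl goes with the step, as it differs from 2-(2-hydroxyethyl)piperidin-1-yl in its rings, its nitrogen count and its hydrogen-bond donors all at once. They also leave open how a morpholine or a piperazine on the same chain carbon, or a longer chain carrying 4-(piperidin-1-yl)piperidin-1-yl, would read in this assay.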